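The source may hold more compounds than are shown below. What is called first, only, known or untested is meant among the compounds shown, and "the series" means these compounds.

Measured compounds in an ADME assay on C8166 cells (Homo sapiens) for cytotoxicity, read by colorimetric assay and MTT assay; a lower number here means that less compound is tolerated, a higher number that more compound is tolerated:
- compound 1 `Cc1cc(C)cc(C(=O)c2c(OCC(=O)Nc3ccc(S(N)(=O)=O)cc3C)ccc3cc(Br)ccc23)c1`: 24500 nM
- compound 2 `Cc1ccc(C)c(C(=O)c2c(OCC(=O)Nc3ccc(S(N)(=O)=O)cc3C)ccc3cc(Br)ccc23)c1`: 14000 nM
- compound 3 `Cc1cc(S(N)(=O)=O)ccc1NC(=O)COc1ccc2cc(Br)ccc2c1C(=O)c1cc(Cl)cc(Br)c1`: 28500 nM

Compound 1 gives the second highest of the three numbers in this assay. The nearest is compound 3, with a 1.2-fold higher number from compound 1 to compound 3 (0.07 log units; within the scatter); the furthest is compound 2, with a 1.8-fold lower number from compound 1 to compound 2 (0.24 log units; within the scatter). Between the other two, a 2.0-fold higher number from compound 2 to compound 3 (0.31 log units; beyond the scatter). All three measured steps swap the aryl group on the carbonyl carbon, and none of them move far.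

Compound 4 `Cc1cc(C)cc(C(=O)c2c(OCC(=O)Nc3ccc(S(N)(=O)=O)cc3C)ccc3cc(C#N)ccc23)c1` differs from compound 1 at another place: cyano in place of bromo on an aromatic carbon. No measured step touches this position; the three steps shown all concern the aryl on the carbonyl, so they give no direct guide to the swap of bromo for cyano. The shared core and the sulfonamide-bearing amide are unchanged. Going by the values given here, with the measured steps all small and no step bearing on this change, compound 4 is expected to stay close to compound 1, with a 1.0-fold lower number from compound 1 to compound 4 (0.01 log units; within the scatter) expected to lie within the scatter. The estimate for compound 4 in this assay is 24000 nM, with a range from 9000 nM to 60000 nM.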

Compound 4, half-maximal cytotoxic concentration: 128000 nM
Compound 4: the middle estimate sits 5.3-fold (0.73 log units) below what was measured, and the stated range ends below it.
By their numbers in this assay, from the lowest: compounds 2, 1 and 3 (each within the scatter of the next, the first and the last beyond it); then compound 4.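

Cyano in place of bromo on this aromatic carbon gives a 5.2-fold higher number from compound 1 to compound 4 (0.72 log units; beyond the scatter) in this assay, so this position can move the number further than any aryl swap on the carbonyl shown here, the largest of which is a 2.0-fold higher number from compound 2 to compound 3 (0.31 log units; beyond the scatter). The change replaces a single bromine with a cyano group that has a triple bond and a hydrogen-bond acceptor, and more compound is tolerated with cyano at this place. Nothing available accounts for the rise.

Open, as far as these compounds go, is whether an amine, a carboxylic acid or a methyl group on this carbon would raise the number as well, or whether the rise is particular to cyano. Also open, from the compounds shown here alone, is whether the same swap gives a similar step with the 2,5-dimethylphenyl or 3-bromo-5-chlorophenyl group on the carbonyl.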